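The source may report more compounds than this note shows. Statements on the series, on what has been measured and on what is new or still open speak of the compounds shown alone.

Measured compounds:
compound 1, `COc1cc(Oc2cccc(Nc3ccccc3)c2)cc(OC)c1CNCc1ccc(F)cc1`: 6770 nM
compound 2, `COc1cc(Oc2cccc(Nc3ccccc3)c2)cc(OC)c1CNCc1ccc(C)cc1`: 11800 nM
compound 3, `COc1cc(Oc2cccc(Nc3ccccc3)c2)cc(OC)c1CN[C@H](C)c1ccccc1`: 18700 nM

In a functional assay on SW-620 cells (Homo sapiens) for inhibition, read by MTT assay, with a stated time of 72 h (on this read-out higher numbers stand for weaker inhibition and lower numbers for stronger inhibition), compound 3 gives the highest of the three numbers. Its gap to compound 2 is within the scatter, so the two cannot be told apart; its gap to compound 1, a 2.8-fold higher number from compound 1 to compound 3 (0.44 log units; beyond the scatter), is a modest but real difference.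

Compound 4, `COc1cc(Oc2cccc(Nc3ccccc3)c2)cc(OC)c1CNCc1ccc(Cl)cc1`, differs from compound 3 by a single change: 4-chlorobenzyl in place of 1-phenylethyl on an amine nitrogen. Within the data shown here, two measured steps bear on this. The 4-fluorobenzyl and 4-methylbenzyl compounds both carry a benzyl with a single group on the ring, as compound 4 does, and exchanging those groups gave a 1.7-fold higher number from compound 1 to compound 2 (0.24 log units; within the scatter). Going from either of them to the 1-phenylethyl of compound 3 gave a 2.8-fold higher number from compound 1 to compound 3 (0.44 log units; beyond the scatter) and a 1.6-fold higher number from compound 2 to compound 3 (0.20 log units; within the scatter). Reversing that move is therefore expected to give a lower number, of about the size seen in those steps, so that compound 4 is expected to land near compounds 1 and 2. The step expected for compound 4 is a 2.2-fold lower number from compound 3 to compound 4 (0.34 log units; beyond the scatter). For compound 4 the estimate is 8500 nM, with a range from 4000 nM to 18000 nM.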

Compound 4, half-maximal inhibitory concentration: 6340 nM
The estimate for compound 4 lay 1.3-fold (0.13 log units) above the measured number, within the range that was stated.
By their numbers in this assay, from the lowest: compounds 4, 1, 2 and 3 (each within the scatter of the next, the first and the last beyond it).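

Among these compounds, the direct exchange of 1-phenylethyl for 4-chlorobenzyl on the amine nitrogen gives a 2.9-fold lower number from compound 3 to compound 4 (0.47 log units; beyond the scatter) in this assay, a second step beyond the scatter alongside the one from compound 1, although the step from compound 2 to compound 3 stays within it and so goes against a clean split. Chloro also joins fluoro and methyl as a third group on the benzyl ring, and with a 1.1-fold lower number from compound 1 to compound 4 (0.03 log units; within the scatter) and a 1.9-fold lower number from compound 2 to compound 4 (0.27 log units; within the scatter), these exchanges cannot be told apart from the scatter. No measurement shown explains any of these steps.

The 1-phenylethyl group differs from these benzyl groups both in its added branch methyl and in its bare ring, and the compounds shown do not separate the two. On these data alone, a plain benzyl would bear on that, and how a methoxy or a nitrile on the ring would compare remains open.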